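The compounds below may be only part of what the source reports. "The series", "measured", "known", "first", "only" and "open" are said of these compounds alone.

Measured in a functional assay on A549 cells (Homo sapiens) for cytotoxicity, read by sulforhodamine B assay; a higher number here means a weaker inhibitor, a lower number a stronger inhibitor:

- Compound 1 `C=C1[C@@H](OC(C)=O)C[C@@H]2[C@](C)(CO[Si](C)(C)C(C)(C)C)[C@H](OC(C)=O)CC[C@@]2(C)[C@@H]1C[C@@H](Nc1ccc(Br)cc1)C1=CCOC1=O` gives 4150 nM
- Compound 2 `C=C1[C@@H](OC(C)=O)C[C@@H]2[C@](C)(COC=O)[C@H](OC(C)=O)CC[C@@]2(C)[C@@H]1C[C@@H](Nc1ccccc1C(=O)O)C1=CCOC1=O` gives 45900 nM
- Compound 3 `C=C1[C@@H](OC(C)=O)C[C@@H]2[C@](C)(COC=O)[C@H](OC(C)=O)CC[C@@]2(C)[C@@H]1C/C=C1/C(=O)OC[C@H]1OC(C)=O` gives 19000 nM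

Compound 1 has the lowest number of the three, so it is the strongest inhibitor in this small set. Compound 3 comes nearest to it, and compound 2 lies furthest away. Attention now turns to compound 4 `C=C1[C@@H](OC(C)=O)C[C@@H]2[C@](C)(CO[Si](C)(C)C(C)(C)C)[C@H](OC(C)=O)CC[C@@]2(C)[C@@H]1C[C@@H](Nc1cccc(F)c1)C1=CCOC1=O`, which has not yet been measured. It differs from compound 1 in one place: 3-fluorophenyl in place of 4-bromophenyl on an amine nitrogen. In words, it carries 3-fluorophenyl in place of 4-bromophenyl on an amine nitrogen. Within the data shown here, no measured pair here isolates a change of this kind, so the data offer no direct guide to its size. The expectation therefore starts from compound 1 at 4150 nM. In this assay, no step beyond the scatter is expected, and any shift would more likely be towards a somewhat higher number. The estimated step is a 1.3-fold higher number from compound 1 to compound 4 (0.12 log units; within the scatter). For compound 4 the expected value is 5500 nM, with an estimated range from 2200 nM to 14000 nM.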

Compound 4, half-maximal inhibitory concentration: 4060 nM
For compound 4 the middle estimate is 1.4-fold (0.13 log units) above the measured one, within the range that was stated.
By their numbers in this assay, from the lowest: compounds 4 and 1 (each within the scatter of the next); then compound 3; then compound 2.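

In this assay, the group on the amine nitrogen of compound 1 tolerates 3-fluorophenyl in place of 4-bromophenyl, with a 1.0-fold lower number from compound 1 to compound 4 (0.01 log units; within the scatter), a step within the scatter. Among these compounds, this is the first reading of a single change at this position, as the earlier compounds offered no pair differing in one place, and it shows that exchanging both the halogen and its place on the ring leaves the number unmoved. No measurement shown explains why these two aryl groups read alike.

The halogen and its place on the ring changed together in this one step, so their separate contributions remain unresolved, and the two could even offset each other. Going by these compounds, whether the halogen is needed at all, and how a plain phenyl or a benzyl group on the same nitrogen would read, also stays open.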